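Formyl-to-bromo swap on the aryl group, compound 3 to compound 4

The source may report more compounds than this note shows. Statements on the series, on what has been measured and on what is new or still open speak of the compounds shown alone.

Measured compounds in a functional assay on MDA-MB-231 cells (Homo sapiens) for inhibition, read by sulforhodamine B assay, with a stated time of 48 h, tested at 10 uM; on this read-out lower numbers stand for less inhibition and higher numbers for more inhibition at the one concentration tested (going by the name of the read-out):
Compound 1 `Brc1cn2ccnc2c(-c2ccc3ncn(C4CCCCC4)c3c2)n1` gives 24.2%.
Compound 2 `c1ccc(-c2cn3ccnc3c(-c3ccc4ncn(C5CCCCC5)c4c3)n2)cc1` gives 41.5%.
Compound 3 `O=Cc1ccc(-c2cn3ccnc3c(-c3ccc4ncn(C5CCCCC5)c4c3)n2)cc1` gives 51.2%.

Compound 3 stands at the top of the three numbers, but one of its two gaps is a number 9.7 percentage points higher from compound 2 to compound 3 (within the scatter), within the scatter, so those two cannot be ordered; the other gap is a number 27 percentage points higher from compound 1 to compound 3 (beyond the scatter), a clear separation. Compound 4 `Brc1ccc(-c2cn3ccnc3c(-c3ccc4ncn(C5CCCCC5)c4c3)n2)cc1` differs from compound 3 by bromo in place of formyl on an aromatic carbon.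

Among the compounds with values here, no measured step exchanges bromo for formyl on this ring. The steps that come closest are a number 17.3 percentage points higher from compound 1 to compound 2 (beyond the scatter) and a number 27 percentage points higher from compound 1 to compound 3 (beyond the scatter), where a bromo on the shared core was replaced by phenyl or 4-formylphenyl, and a number 9.7 percentage points higher from compound 2 to compound 3 (within the scatter), where the formyl entered; that last step stayed within the scatter. With bromo in place of formyl, compound 4 is expected to land near compound 2 and compound 3, with no change beyond the scatter. The expected step is a number 6.2 percentage points lower from compound 3 to compound 4 (within the scatter). Compound 4 is estimated at 45% in this assay, within 30% to 60%.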

Compound 4, a percentage reported as inhibition, at one concentration (the size of the read-out at that concentration, not a potency): 22.8%
The estimate for compound 4 lay 22.2 percentage points above the measured number; measured number below the stated range.
By their numbers in this assay, from the lowest: compounds 4 and 1 (each within the scatter of the next); then compounds 2 and 3 (each within the scatter of the next).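

In this assay the position para to a large group on the six-membered aromatic ring of carbon only proves responsive: the step of a number 18.7 percentage points lower from compound 2 to compound 4 (beyond the scatter) and the step of a number 28.4 percentage points lower from compound 3 to compound 4 (beyond the scatter) both lie beyond the scatter, whereas the formyl step from the unsubstituted phenyl had stayed within it. The step of a number 1.4 percentage points lower from compound 1 to compound 4 (within the scatter) lies within the scatter, so an aryl group in place of the bromo on the shared core does not by itself carry the higher numbers of the phenyl and 4-formylphenyl compounds, and compound 4 goes against any such reading. Nothing available here accounts for the effect of bromo at this position.

On these data alone, whether the lower number is particular to bromo, or is shared by other groups at this position such as chloro, methoxy, an amine or a carboxylic acid, remains open. As far as these compounds go, with each compound read at one concentration in one cell line, how these differences relate to potency also remains open.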